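Swapping a Hydroxy-Methoxyphenyl for a Nitrophenyl Group

A few compounds are considered here, and "the series" means these few. Any claim that something is new, unique, unknown or untested is made for them only; others in the source may bear on it.

Of the compounds shown here, two that share a core have been measured in an assay on isolated protein for inhibition of Maltase-glucoamylase (Homo sapiens), with a stated time of 15 min; a higher number here means a weaker inhibitor, a lower number a stronger inhibitor. Compound 1 `COc1ccc(O)c(/C=N/NC(=O)c2ccc(-c3nc4ccccc4s3)cc2)c1` gives 6500 nM. Compound 2 `O=C(N/N=C/c1ccc(O)cc1O)c1ccc(-c2nc3ccccc3s2)cc1` gives 5580 nM. Of these two numbers, compound 1 stands highest, with compound 2 nearest; the step of a 1.2-fold lower number from compound 1 to compound 2 (0.07 log units; within the scatter) lies within the scatter, so the two compounds cannot be separated on this evidence.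

Compound 3 `O=C(N/N=C/c1ccc([N+](=O)[O-])cc1)c1ccc(-c2nc3ccccc3s2)cc1` has not yet been measured. It differs from compound 1 in one place: 4-nitrophenyl in place of 2-hydroxy-5-methoxyphenyl on a carbon with a double bond to nitrogen. Within the data shown here, the single measured step, which exchanged one substituted phenyl for another on the same carbon, left the number unchanged within the scatter. Among the measured compounds shown here, that step kept a hydrogen-bond donor on the ring, whereas the change to compound 3 removes it, so no measured step bears directly on this exchange. A step that stays within the scatter is therefore the most reasonable expectation, with a mild lean toward a higher number. Compound 3 is expected to give about 7500 nM, with a range from 2500 nM to 22000 nM. That estimate corresponds to an expected step of a 1.2-fold higher number from compound 1 to compound 3 (0.06 log units; within the scatter).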

Compound 3, half-maximal inhibitory concentration: 26400 nM
The estimate for compound 3 lay 3.5-fold (0.55 log units) below the measured number, outside the stated range (above it).
By their numbers in this assay, from the lowest: compounds 2 and 1 (each within the scatter of the next); then compound 3.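

In this assay the carbon with a double bond to nitrogen turns out not to treat every substituted phenyl alike: 4-nitrophenyl in place of 2-hydroxy-5-methoxyphenyl gives a 4.1-fold higher number from compound 1 to compound 3 (0.61 log units; beyond the scatter) and 4-nitrophenyl in place of 2,4-dihydroxyphenyl gives a 4.7-fold higher number from compound 2 to compound 3 (0.67 log units; beyond the scatter) so both steps are modest but beyond the scatter. Among these compounds, the earlier exchange of one hydroxy-bearing ring for another moved nothing that could be told apart, whereas this change, which leaves the shared core untouched, is the first at this position to produce a real difference, and it goes toward a weaker inhibitor. Nothing measured on these groups accompanies the result, so the step remains without an explanation here.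

The compounds shown leave open whether the step follows the departure of the hydroxy groups or the arrival of the nitro group, since the two changes occur together in compound 3. An unsubstituted phenyl on the same carbon would pull these two changes apart, and a ring bearing an amine or a carboxylic acid would show how far the trend extends to other groups.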